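Adding a second chloro to a purine-type core: compound 4

The source may report more compounds than this note shows. Statements on the series, on what has been measured and on what is new or still open speak of the compounds shown alone.

Compounds measured so far:
compound 1 `ClCc1ccccc1Cn1cnc2c(Cl)nc(Cl)nc21` — 2400 nM
compound 2 `ClCc1cccc(Cn2cnc3c(Cl)ncnc32)c1` — 17400 nM
compound 3 `ClCc1ccc(Cn2cnc3nc(Cl)nc(Cl)c32)cc1` — 11200 nM

In a functional assay on A498 cells (Homo sapiens) for cytotoxicity, read by sulforhodamine B assay, with a stated time of 48 h (a higher number here means a weaker inhibitor of growth, a lower number a stronger inhibitor of growth), compound 2 gives 17400 nM, the highest of the three numbers. Compound 3 sits nearest to it, and that gap lies within the scatter, so the two cannot be ranked against each other. Compound 1 lies furthest away, and that gap lies beyond the scatter: compound 1, with its value of 2400 nM, is clearly the stronger inhibitor of growth of the pair.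

Compound 4 `ClCc1cccc(Cn2cnc3c(Cl)nc(Cl)nc32)c1` differs from compound 2 in one place: chloro in place of hydrogen on an aromatic carbon. Going by the values given here, no measured pair in this set shows that single change alone, so its size is not known directly. What the data show is that both compounds carrying two chloro groups on the shared core, compound 1 and compound 3, give lower numbers than compound 2. On that basis compound 4 is expected to move to a lower number than compound 2, a step of a 2.5-fold lower number from compound 2 to compound 4 (0.40 log units; beyond the scatter), though with wide uncertainty. The estimate for compound 4 in this assay is therefore 7000 nM, with a range from 2000 nM to 20000 nM.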

Compound 4, concentration for 50% growth inhibition: 2390 nM
For compound 4 the middle estimate is 2.9-fold (0.47 log units) above the measured one; low and high end bracket the measured number.
By their numbers in this assay, from the lowest: compounds 4 and 1 (each within the scatter of the next); then compounds 3 and 2 (each within the scatter of the next).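

In this assay, going by these compounds alone, placing chloro in place of hydrogen on the aromatic carbon between two ring nitrogen atoms gives a 7.3-fold lower number from compound 2 to compound 4 (0.86 log units; beyond the scatter), which is the first direct reading of this single change in the set. Until now, the effect of this chloro could only be inferred from compounds that also differed elsewhere, whereas this pair isolates it on an otherwise unchanged structure. Nothing in the data presented accounts for the size of this step.

The compounds shown leave open whether this position specifically favours chloro or whether another group there, such as an amine, a methoxy group or a methyl group, would give a similar number. They also leave open whether the step would keep its size with the chloromethyl group replaced by a longer chain.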